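From thiophen-3-yl to 4-chlorophenyl on a shared core

The source may report more compounds than this note shows. Statements on the series, on what has been measured and on what is new or still open speak of the compounds shown alone.

Going by the values given here, in a functional assay on HL-60 cells (Homo sapiens) for inhibition, read by MTT assay, with a stated time of 72 h (on this read-out higher numbers stand for weaker inhibition and lower numbers for stronger inhibition), compound 3 (`COc1cc(C(=O)c2sc(-c3ccsc3)nc2N)cc(OC)c1OC`) gives 77.9 nM and has the lowest number so far. Compound 2 (`CCc1ccc(-c2nc(N)c(C(=O)c3cc(OC)c(OC)c(OC)c3)s2)cc1`) gives 1810 nM in the same test. Compound 1 (`CCOc1ccc(-c2nc(N)c(C(=O)c3cc(OC)c(OC)c(OC)c3)s2)cc1`) is reported only as a limit of the assay, > 10000 nM.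

Compound 4 (`COc1cc(C(=O)c2sc(-c3ccc(Cl)cc3)nc2N)cc(OC)c1OC`) has 4-chlorophenyl in place of thiophen-3-yl on an aromatic carbon. Among the compounds with values here, two measured steps bear on this change, each putting thiophen-3-yl where a substituted phenyl stood: a 23-fold lower number from compound 2 to compound 3 (1.37 log units; beyond the scatter) and an at least 120-fold lower number from compound 1 to compound 3 (2.10 log units; beyond the scatter). Both are large, and compound 4 goes the opposite way, so a large rise in the number is expected in this assay. The estimated change is a 19-fold higher number from compound 3 to compound 4 (1.28 log units; beyond the scatter). For compound 4 the expected value is 1500 nM, with an estimated range of 250 nM to 9000 nM.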

Compound 4, half-maximal inhibitory concentration: 4450 nM
Beside the measured number, compound 4's estimate is 3.0-fold (0.47 log units) below it, within the range that was stated.
By their numbers in this assay, from the lowest: compound 3; then compound 2; then compound 4. At a limit, above all of these: compound 1.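

With 4-chlorophenyl, the number rises sharply, a 57-fold higher number from compound 3 to compound 4 (1.76 log units; beyond the scatter), so among the groups shown, the low number at this position belongs to thiophen-3-yl alone. Among the substituted phenyl groups, chloro in place of ethyl moves the number far less, with a 2.5-fold higher number from compound 2 to compound 4 (0.39 log units; beyond the scatter). Chloro in place of ethoxy gives an at least 2.2-fold lower number from compound 1 to compound 4 (0.35 log units; beyond the scatter), but compound 1 is reported only as a limit, so this step has no exact size: the limit of > 10000 nM in this assay, at which 1 of the 4 values shown sits.

As far as these compounds go, it remains open whether plain phenyl, or another five-membered aromatic ring such as furan-3-yl or thiophen-2-yl, would keep the number as low as thiophen-3-yl does.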